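Dichlorophenyl Replaced by Difluorophenyl on the Ring Nitrogen

The compounds below may be only part of what the source reports. "The series", "measured", "known", "first", "only" and "open" are said of these compounds alone.

Three measured compounds share one core and differ only in the group on an amine nitrogen in a ring. In a functional assay on CHO cells with adenosine receptor A1 (Homo sapiens) as the target, read by cAMP accumulation and immunoassay, with a stated time of 6 min, tested at 1 uM (on this read-out higher numbers stand for a weaker effect at the one concentration tested and lower numbers for a stronger effect), compound 1 `CC(C)N1CCN(Cc2csc(N)c2C(=O)c2ccc(Cl)cc2)CC1` gives 7.3%, compound 2 `Nc1scc(CN2CCN(c3cc(Cl)cc(Cl)c3)CC2)c1C(=O)c1ccc(Cl)cc1` gives -69%, and compound 3 `Nc1scc(CN2CCN(c3ccccc3F)CC2)c1C(=O)c1ccc(Cl)cc1` gives -9.2%. Compound 2 stands lowest of the three, the strongest effect at the tested concentration; both steps away from it, a number 59.8 percentage points higher from compound 2 to compound 3 (beyond the scatter) and the reverse of a number 76.3 percentage points lower from compound 1 to compound 2 (beyond the scatter), are large, while a number 16.5 percentage points lower from compound 1 to compound 3 (beyond the scatter) is modest.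

Compound 4 `Nc1scc(CN2CCN(c3c(F)cccc3F)CC2)c1C(=O)c1ccc(Cl)cc1` has not been measured. It differs from compound 2 in one place: 2,6-difluorophenyl in place of 3,5-dichlorophenyl on an amine nitrogen in a ring. The step that bears most on this change is a number 59.8 percentage points higher from compound 2 to compound 3 (beyond the scatter), where a fluorophenyl took the place of the dichlorophenyl. A difluorophenyl is expected to fall closer to compound 3 than to compound 2, and a rise of a number 44 percentage points higher from compound 2 to compound 4 (beyond the scatter) is expected. Among the compounds with values here, no second difluorophenyl analogue exists among the measured compounds, and the range is therefore wide. Compound 4 is estimated at -25%, with a range from -60% to 5%.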

Compound 4, a percentage reported as activity, at one concentration (the size of the read-out at that concentration, not a potency): -65%
Estimate against measurement, compound 4: 40 percentage points above, and the stated range ends above it.
By their numbers in this assay, from the lowest: compounds 2 and 4 (each within the scatter of the next); then compound 3; then compound 1.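

In this assay, the 2,6-difluorophenyl and 3,5-dichlorophenyl groups on the amine nitrogen in a ring cannot be told apart (a number 4 percentage points higher from compound 2 to compound 4 (within the scatter)), so the low number at this position does not require chlorine. The change from compound 3 shows that one more fluoro on the aromatic ring, in place of hydrogen, can alone carry a large step (a number 55.8 percentage points lower from compound 3 to compound 4 (beyond the scatter)). The step from isopropyl is also large (a number 72.3 percentage points lower from compound 1 to compound 4 (beyond the scatter)), but compound 3 goes against any rule that a phenyl ring on this nitrogen is enough, as its own step from compound 1 is only modest. Nothing given here accounts for these differences. The compounds shown leave open where a 3,5-difluorophenyl or a 2,6-dichlorophenyl would fall. They also leave open where an unsubstituted phenyl would stand relative to compound 3.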